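Compound 2 to compound 3: oxy replaced by amino

The compounds below may be only part of what the source reports. "The series", "measured", "known", "first", "only" and "open" are said of these compounds alone.

For the measured compounds named here, in a functional assay on Malme-3M cells (Homo sapiens) for antiproliferative activity, read by sulforhodamine B assay, with a stated time of 48 h (a lower number here means a stronger inhibitor, a higher number a weaker inhibitor), compound 1 `C/C=C(\C)C(=O)O[C@H]1C=CC(=O)O[C@H]1CCC(=O)[C@H](C)O` gives 24000 nM and compound 2 `C/C=C(\C)C(=O)O[C@H]1C=CC(=O)O[C@H]1COC(=O)[C@H](C)O` gives 13000 nM, so compound 2 stands within the scatter of the only other measured value. Compound 3 `C/C=C(\C)C(=O)O[C@H]1C=CC(=O)O[C@H]1CNC(=O)[C@H](C)O` has not yet been measured. It carries ((1-hydroxyethyl)carbonyl)amino in place of ((1-hydroxyethyl)carbonyl)oxy on a saturated chain carbon bound to a saturated ring carbon. Going by the values given here, only one measured step bears on this, at the same place: a 1.8-fold lower number from compound 1 to compound 2 (0.27 log units; within the scatter), with ((1-hydroxyethyl)carbonyl)oxy in place of ((1-hydroxyethyl)carbonyl)methyl. Among the compounds with values here, no measured step involves the amino group, so the basis is thin. With a 1.8-fold lower number from compound 1 to compound 2 (0.27 log units; within the scatter) as the guide, no change beyond the scatter is expected in either direction, and the estimated step is a 1.2-fold higher number from compound 2 to compound 3 (0.09 log units; within the scatter). The estimate for compound 3 is 16000 nM, with an expected range of 7000 nM to 38000 nM.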

Compound 3, half-maximal inhibitory concentration: 28000 nM
Estimate against measurement, compound 3: 1.8-fold (0.24 log units) below; low and high end bracket the measured number.
By their numbers in this assay, from the lowest: compounds 2, 1 and 3 (each within the scatter of the next, the first and the last beyond it).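

In this assay, for the compounds shown here, the exchange of ((1-hydroxyethyl)carbonyl)oxy for ((1-hydroxyethyl)carbonyl)amino gives a 2.2-fold higher number from compound 2 to compound 3 (0.33 log units; beyond the scatter), the first step on this saturated chain carbon bound to a saturated ring carbon that clears the usual scatter, though only modestly. Going by these compounds alone, the exchange of ((1-hydroxyethyl)carbonyl)methyl for ((1-hydroxyethyl)carbonyl)amino gives a 1.2-fold higher number from compound 1 to compound 3 (0.07 log units; within the scatter), so compound 1 and compound 3 cannot be told apart and only the pair of compound 2 and compound 3 is separated. Nothing available accounts for that separation.

From the compounds shown here alone, all three compounds keep the 1-hydroxyethyl end, so it remains open how a longer chain, an amine or a carboxylic acid on this carbon would read out. Going by these compounds, it also remains open whether the modest separation between compound 2 and compound 3 would hold with a different end group on the same linkers.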